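A few compounds are considered here, and "the series" means these few. Any claim that something is new, unique, unknown or untested is made for them only; others in the source may bear on it.

Compound 2 `COc1cc2ncnc(NCc3cccc(NC(=O)Nc4ccc(C(C)(C)C)cc4)c3)c2cc1OC` gives the lower of the two numbers measured in a functional assay on A549 cells (Homo sapiens) for antiproliferative activity, read by MTT assay (a higher number here means a weaker inhibitor, a lower number a stronger inhibitor), at 5210 nM, while compound 1 `COc1cc2ncnc(NCc3cccc(NC(=O)Nc4ccccc4)c3)c2cc1OC` gives 17100 nM. Going by the values given here, the single measured step, a 3.3-fold lower number from compound 1 to compound 2 (0.52 log units; beyond the scatter), came from adding a tert-butyl group. Compound 3 `COc1cc2ncnc(NCc3cccc(NC(=O)Nc4ccccc4Cl)c3)c2cc1OC` moves the other way: 2-chlorophenyl in place of 4-(tert-butyl)phenyl on an amide-type nitrogen. Among the compounds with values here, that removes the tert-butyl group that went with the lower number and brings in a chlorine, for which no measured step exists. A move back toward the number of compound 1 is therefore expected, roughly a 2.5-fold higher number from compound 2 to compound 3 (0.40 log units; beyond the scatter). Compound 3 is expected to give about 13000 nM, within 4500 nM to 38000 nM.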

Compound 3, half-maximal inhibitory concentration: 15200 nM
For compound 3 the middle estimate is 1.2-fold (0.07 log units) below the measured one; the range from low to high includes it.
By their numbers in this assay, from the lowest: compound 2; then compounds 3 and 1 (each within the scatter of the next).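

Chloro in place of hydrogen on an aromatic carbon gives a 1.1-fold lower number from compound 1 to compound 3 (0.05 log units; within the scatter) in this assay, so this chlorine does not set compound 3 apart from the unsubstituted phenyl of compound 1. The other step, a 2.9-fold higher number from compound 2 to compound 3 (0.47 log units; beyond the scatter), shows that the lower number of compound 2 is not kept when 2-chlorophenyl replaces 4-(tert-butyl)phenyl. Nothing measured here explains this difference.

Still open, as far as these compounds go, is how a methoxy group, an amine or a carboxylic acid on this ring would compare with tert-butyl. Also open, from the compounds shown here alone, is whether chlorine elsewhere on the ring would match 2-chlorophenyl.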